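Swapping a methyl for fluoro on the biaryl end

The source may hold more compounds than are shown below. What is called first, only, known or untested is meant among the compounds shown, and "the series" means these compounds.

Measured compounds and their values in a functional assay for agonist activity at G protein-coupled receptor 88 (Homo sapiens), read by HTRF and cAMP accumulation; on this read-out higher numbers stand for an effect only at larger amounts of compound and lower numbers for an effect already at smaller amounts:
- compound 1, `CC(C)C[C@H](N)CN(C(=O)[C@@H]1C[C@H]1c1ccccc1)c1ccc(-c2ccsc2)cc1`, gives 1200 nM
- compound 2, `CC(C)C[C@H](N)CN(C(=O)[C@@H]1C[C@H]1c1ccccc1)c1ccc(C2=CCCC2)cc1`, gives 1200 nM
- compound 3, `Cc1ccc(-c2ccc(N(C[C@@H](N)CC(C)C)C(=O)[C@@H]3C[C@H]3c3ccccc3)cc2)cc1`, gives 360 nM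

Among these three, compound 3 stands with the lowest number, and both of its neighbours lie beyond the scatter from it: a 3.3-fold lower number from compound 1 to compound 3 (0.52 log units; beyond the scatter) and a 3.3-fold lower number from compound 2 to compound 3 (0.52 log units; beyond the scatter). Compound 1 and compound 2, by contrast, sit together, as no change at the digits printed from compound 1 to compound 2 (within the scatter) shows.

Compound 4, `CC(C)C[C@H](N)CN(C(=O)[C@@H]1C[C@H]1c1ccccc1)c1ccc(-c2ccc(F)cc2)cc1`, differs from compound 3 by one small change: fluoro in place of methyl on an aromatic carbon. The shared core and the left-hand part of the molecule are untouched.

For the measured compounds named here, none of the measured steps touches this exact change. The two steps that reach compound 3 both exchange a non-phenyl ring for the 4-methylphenyl group, and both are modest in size. They say that a phenyl-type ring at this position goes with a lower number, but nothing about what a fluoro rather than a methyl on that ring does. In this assay the expectation for compound 4 is therefore a number close to that of compound 3, with a 1.3-fold higher number from compound 3 to compound 4 (0.10 log units; within the scatter) as the expected step, inside the scatter. The estimate for compound 4 is 450 nM, in a range from 200 nM to 1000 nM.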

Compound 4, half-maximal effective concentration: 900 nM
Compound 4: the middle estimate sits 2.0-fold (0.30 log units) below what was measured; the measured number falls inside the stated range.
By their numbers in this assay, from the lowest: compound 3; then compounds 4, 1 and 2 (each within the scatter of the next).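

In this assay, the group para to a large group on the outer ring clearly matters: exchanging one heavy atom for another gives a 2.5-fold higher number from compound 3 to compound 4 (0.40 log units; beyond the scatter). The earlier compounds shown here suggested that a phenyl-type ring here might be enough for a lower number, but compound 4 goes against that. Its 4-fluorophenyl group stays within the scatter of both non-phenyl rings (a 1.3-fold lower number from compound 2 to compound 4 (0.12 log units; within the scatter); a 1.3-fold lower number from compound 1 to compound 4 (0.12 log units; within the scatter)), so among these compounds only the 4-methylphenyl group stands apart. No available measurement explains why methyl and fluoro differ at this position.

Going by these compounds, it remains open how a plain phenyl ring, with hydrogen in this place, would compare, and so whether methyl lowers the number, fluoro raises it, or both happen. Also open, on these data alone, is whether the trend continues with a longer chain such as ethyl or propyl, with chloro or methoxy, or with an amine or a carboxylic acid at the same place on the ring.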